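This account rests on a few compounds, and the source may have more. Where it says the series, first, only, none or still open, it means among the compounds named here.

Measured so far in a functional assay on HT-29 cells (Homo sapiens) for inhibition, read by MTT assay, with a stated time of 48 h; a higher number here means a weaker inhibitor, a lower number a stronger inhibitor:

compound 1 `CN1CCN(c2ccc(Nc3ncc4c(n3)N(C3CCCC3)CC(=O)N4)nc2)CC1`: 26500 nM
compound 2 `O=C1CN(C2CCCC2)c2nc(Nc3ccc(N4CCCCC4)cn3)ncc2N1`: 21100 nM
compound 3 `CN1CCN(c2ccc(Nc3ncc4c(n3)N(C3CCCC3)CC(=O)N4C)cc2)CC1`: 7560 nM

Compound 1 and compound 2 share a core and differ in one place: piperidin-1-yl in place of 4-methylpiperazin-1-yl on an aromatic carbon. The step this change made, a 1.3-fold lower number from compound 1 to compound 2 (0.10 log units; within the scatter), is small. Compound 3 carries a different core; how the cores of compound 3 and compound 1 differ is not broken down here. Among the three measured compounds, compound 3 gives the lowest number, and its distance to compound 2 and to compound 1 is beyond the scatter in both cases.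

Compound 4 `CN1C(=O)CN(C2CCCC2)c2nc(Nc3ccc(N4CCCCC4)cc3)ncc21` is not yet measured. It stands to compound 3 as compound 2 stands to compound 1: piperidin-1-yl in place of 4-methylpiperazin-1-yl on an aromatic carbon. The two changes are the same kind of change but not the same one. In compound 1 the exchanged group sits on a six-membered aromatic ring with one nitrogen, two atoms from the ring nitrogen, para to a large group; in compound 3 it sits on a six-membered aromatic ring of carbon only, para to a large group. Whether the step transfers across this difference in surroundings is not shown by any other pair here, so the expectation rests on one step only.

Compound 4 is expected at 6000 nM in this assay, with a range from 2500 nM to 14000 nM. The expected step, a 1.3-fold lower number from compound 3 to compound 4 (0.10 log units; within the scatter), is set to resemble a 1.3-fold lower number from compound 1 to compound 2 (0.10 log units; within the scatter) because that step stayed within the scatter.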

Compound 4, half-maximal inhibitory concentration: 9860 nM
Beside the measured number, compound 4's estimate is 1.6-fold (0.22 log units) below it; low and high end bracket the measured number.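

In this assay, the exchange of 4-methylpiperazin-1-yl for piperidin-1-yl on an aromatic carbon of a six-membered aromatic ring of carbon only gives a 1.3-fold higher number from compound 3 to compound 4 (0.12 log units; within the scatter), so compound 3 and compound 4 cannot be told apart in this read-out. The exchange therefore carries from one core to the other as a step too small to read on both, and the opposite directions of the two steps carry no weight: the same change on two cores in this assay, a 1.3-fold lower number (0.10 log units; within the scatter) from compound 1 to compound 2 and a 1.3-fold higher number (0.12 log units; within the scatter) from compound 3 to compound 4, 1.6-fold (0.21 log units) apart, within the scatter of two such steps

This rests on two pairs only, so it shows that the second ring nitrogen of the 4-methylpiperazin-1-yl group can be given up on these two cores at these high numbers, but it does not show that the same holds on any other core or in a series with much lower numbers.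

Open, as far as these compounds go, is whether a group of another kind in the same place, such as morpholin-4-yl, an open-chain dimethylamino group or a carboxylic acid, would move the number beyond the scatter on either core. Also open is which part of the difference between the cores goes with the lower numbers of compound 3 and compound 4, since no pair shown changes those parts one at a time.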